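The source may report more compounds than this note shows. Statements on the series, on what has been measured and on what is new or still open speak of the compounds shown alone.

Measured in a physicochemical assay for solubility, read by HPLC, with a stated time of 24 h; a lower number here means a less soluble compound, a higher number a more soluble compound:
compound 1 `O=C1O[C@@H](CO)CN1c1ccc(-n2cc(-c3ccccn3)cn2)c(F)c1` — 56400 nM
compound 2 `CCN1CCN(C[C@H]2CN(c3ccc(-n4cc(-c5ccccn5)cn4)c(F)c3)C(=O)O2)CC1` — 706000 nM
compound 3 `CCC(=O)NC[C@H]1CN(c2ccc(-n3cc(-c4ccccn4)cn3)c(F)c2)C(=O)O1` — 147000 nM

Compound 2 stands highest of the three in this assay; compound 3 is nearest, compound 1 furthest, with a 13-fold higher number from compound 1 to compound 2 (1.10 log units; beyond the scatter) separating them.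

The next step goes from compound 2 to compound 4 `CN(C)S(=O)(=O)NC[C@H]1CN(c2ccc(-n3cc(-c4ccccn4)cn3)c(F)c2)C(=O)O1`. The change is (dimethylsulfamoyl)amino in place of 4-ethylpiperazin-1-yl on a saturated chain carbon bound to a saturated ring carbon.

For the measured compounds named here, two measured steps bear on it. The closest comparison is a 4.8-fold lower number from compound 2 to compound 3 (0.68 log units; beyond the scatter), where the same 4-ethylpiperazin-1-yl left this position and propanoylamino entered. The pair of steps from compound 1, a 13-fold higher number from compound 1 to compound 2 (1.10 log units; beyond the scatter) and a 2.6-fold higher number from compound 1 to compound 3 (0.42 log units; beyond the scatter), points the same way: relative to hydroxy at this position, 4-ethylpiperazin-1-yl raised the number far more than propanoylamino did. Nothing measured here covers (dimethylsulfamoyl)amino itself, so the step from compound 2 to compound 3 is taken as the nearest guide, with a wide range.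

On that basis a modest drop is expected in this assay, a 5.9-fold lower number from compound 2 to compound 4 (0.77 log units; beyond the scatter). Compound 4 is estimated at 120000 nM, within a range of 40000 nM to 350000 nM.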

Compound 4, solubility: 472000 nM
Compound 4: middle estimate off by 3.9-fold (0.59 log units), on the low side; the measured number lies above the stated range.
By their numbers in this assay, from the lowest: compound 1; then compound 3; then compounds 4 and 2 (each within the scatter of the next).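

With a 1.5-fold lower number from compound 2 to compound 4 (0.17 log units; within the scatter) in this assay there is no separating (dimethylsulfamoyl)amino, which has no ring, from 4-ethylpiperazin-1-yl, which has a six-membered non-aromatic ring, on a saturated chain carbon bound to a saturated ring carbon. The group on the amine nitrogen also counts: dimethylsulfamoyl in place of propanoyl gives a 3.2-fold higher number from compound 3 to compound 4 (0.51 log units; beyond the scatter) and so a number level with that of the 4-ethylpiperazin-1-yl compound, and the series now holds two groups well clear of hydroxy, as an 8.4-fold higher number from compound 1 to compound 4 (0.92 log units; beyond the scatter) shows for the new one. Nothing measured in this set accounts for these differences.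

From the compounds shown here alone, it remains open whether the result depends on the sulfonyl unit or on its dimethylamino end, which a methanesulfonyl group on the same amine nitrogen would help to separate. Going by these compounds, how a carboxylic acid or a morpholine ring at this place would compare with 4-ethylpiperazin-1-yl and (dimethylsulfamoyl)amino in this assay also remains open.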